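Ethyl to methyl on the anilide of compound 3

A few compounds are considered here, and "the series" means these few. Any claim that something is new, unique, unknown or untested is made for them only; others in the source may bear on it.

Compound 3 `CCc1cccc(NC(=O)CN2CCN(c3ccccn3)CC2)c1` stands highest of the two numbers recorded in a functional assay on cells for agonist activity at D(4) dopamine receptor (Homo sapiens), read by TR-FRET and cAMP accumulation, with a stated time of 30 min; on this read-out higher numbers stand for larger maximal responses and lower numbers for smaller maximal responses: compound 3 gives 58%. The nearest is compound 2 `Cc1cccc(NC(=O)CN2CCC(c3ccccc3)CC2)c1`, which in this assay gives 32.9%, a gap beyond the scatter. Compound 1 `CCc1cccc(NC(=O)CN2CCN(c3ccc(Cl)cn3)CC2)c1` in this assay is reported as "not active" (no number reported), with no number. Compound 4 `Cc1cccc(NC(=O)CN2CCN(c3ccccn3)CC2)c1` has not yet been measured in this assay. It differs from compound 3 in one place: hydrogen in place of methyl on a saturated chain carbon bound to an aromatic carbon. Among the compounds with values here, no pair of measured compounds shows this same change; compound 2 differs from compound 3 in more than one place, so its lower value cannot be assigned to the methyl alone. A small step is expected from compound 3 to compound 4 in this assay, of size a number 6 percentage points lower from compound 3 to compound 4 (within the scatter), within the scatter. Compound 4 is estimated at 52%, between 30% and 75%.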

Compound 4, largest response reached (Emax), in percent of the reference or control that the assay uses: 64.2%
Beside the measured number, compound 4's estimate is 12.2 percentage points below it; the range from low to high includes it.
By their numbers in this assay, from the lowest: compound 2; then compounds 3 and 4 (each within the scatter of the next).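

In this assay, within the data shown here, the change from ethyl to methyl gives a number 6.2 percentage points higher from compound 3 to compound 4 (within the scatter) as the first reading of a single change at this place. The maximal response therefore holds with either 3-ethylphenyl or 3-methylphenyl in this one pair, and the size of the chain on this saturated carbon does not separate the two compounds. No measurement available here bears on why they read alike.

Open, going by these compounds, is whether a longer chain such as propyl, or a methoxy group, keeps this response. Also open, on these data alone, is whether ethyl and methyl read alike on the core of compound 2.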